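The source may report more compounds than this note shows. Statements on the series, on what has been measured and on what is new or still open speak of the compounds shown alone.

Compound 3 `CC(=O)N(Cc1cccc(F)c1F)Cc1cn(S(=O)(=O)c2ccc(C)cc2)c2ccccc12` is the highest of the three compounds measured in a functional assay on 3T3-L1 cells (Mus musculus) for inhibition, with a stated time of 20 min, tested at 20 uM (a higher number here means more inhibition at the concentration tested (going by the name of the read-out), a lower number less inhibition), where compound 3 gives 57.5%. Compound 1 `O=S(=O)(c1ccc(F)cc1)n1cc(CNCc2cccc(F)c2F)c2ccccc21` gives 21% in this assay, and compound 2 `O=S(=O)(c1ccc(F)cc1)N(Cc1cccc(F)c1F)Cc1cn(S(=O)(=O)c2ccc(F)cc2)c2ccccc12` gives -20%. Compound 4 `CC(=O)N(Cc1cccc(F)c1F)Cc1cn(S(=O)(=O)c2ccc(F)cc2)c2ccccc12` differs from compound 3 by fluoro in place of methyl on an aromatic carbon. Within the data shown here, the only measured step, a number 41 percentage points lower from compound 1 to compound 2 (beyond the scatter), concerns a different change at the amine nitrogen, so no measured step bears directly on a fluoro in place of methyl on the aromatic ring. Compound 2 also carries a (4-fluorophenyl)sulfonyl on the core and sits far below compound 3, but it differs in more than one place. With nothing closer to go on, the expected step of a number 7.5 percentage points lower from compound 3 to compound 4 (within the scatter) is none beyond the scatter, and compound 4 is estimated at 50%, between 30% and 70%.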

Compound 4, a percentage reported as inhibition, at one concentration (the size of the read-out at that concentration, not a potency): 25.8%
For compound 4 the middle estimate is 24.2 percentage points above the measured one; measured number outside the range, below it.
By their numbers in this assay, from the lowest: compound 2; then compounds 1 and 4 (each within the scatter of the next); then compound 3.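

With the acetyl on the amine nitrogen held constant in this assay, (4-fluorophenyl)sulfonyl in place of (4-methylphenyl)sulfonyl gives a number 31.7 percentage points lower from compound 3 to compound 4 (beyond the scatter), so the group on this aromatic carbon matters to the read-out. With the (4-fluorophenyl)sulfonyl on the core held constant, acetyl in place of (4-fluorophenyl)sulfonyl on the amine nitrogen gives a number 45.8 percentage points higher from compound 2 to compound 4 (beyond the scatter), while acetyl in place of hydrogen gives a number 4.8 percentage points higher from compound 1 to compound 4 (within the scatter). No measurement available here explains the effect of the fluoro for methyl change. From the compounds shown here alone, it remains open whether a chloro or methoxy group on this aromatic carbon would behave like the methyl or the fluoro. A longer acyl chain on the amine nitrogen is equally unresolved.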